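A few compounds are considered here, and "the series" means these few. Any claim that something is new, unique, unknown or untested is made for them only; others in the source may bear on it.

The series is followed in a functional assay on A549 cells (Homo sapiens) for antiproliferative activity, read by MTT assay, with a stated time of 48 h; on this read-out higher numbers stand for weaker inhibition and lower numbers for stronger inhibition. Compound 1 `COc1ccccc1-n1nncc1CN1C(=O)C2(C(C#N)=C(N)Oc3c2c2nc4ccccc4nc2c2ccccc32)c2ccccc21` reaches only the limit of the method, > 50000 nM, so it gives no number. One further result in the set, (the limit of > 50000 nM in this assay, at which 1 of the 2 values shown sits), is a limit and not a number. Going by the values given here, compound 2 `CCc1ccccc1-n1nncc1CN1C(=O)C2(C(C#N)=C(N)Oc3c(N)cc4nc5ccccc5nc4c32)c2ccccc21` gives 24600 nM, the one numerical value in this assay so far, and thus stands as the sole fixed point for the series. Compound 3 `CC(=O)Nc1ccc(-n2nncc2CN2C(=O)C3(C(C#N)=C(N)Oc4c(N)cc5nc6ccccc6nc5c43)c3ccccc32)cc1` is the next compound for this assay. It differs from compound 2 by 4-acetamidophenyl in place of 2-ethylphenyl on an aromatic nitrogen. Among the compounds with values here, no step between measured compounds is available to size the effect of this change, so the expectation rests on compound 2 alone. The expected step from compound 2 to compound 3 is a 1.1-fold higher number from compound 2 to compound 3 (0.06 log units; within the scatter), none beyond the scatter in either direction. Compound 3 is therefore estimated at 28000 nM, with a range from 8000 nM to 50000 nM, and a real chance that only a limit is returned.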

Compound 3, half-maximal inhibitory concentration: > 50000 nM
Compound 3 ended at the assay's limit; the forecaster's own chance of this, stated with the estimate: 35%; at least 1.7-fold (0.25 log units) between middle value and limit.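

Going by these compounds alone, this is the first step at this position, on an aromatic nitrogen of the five-membered ring: in this assay, 4-acetamidophenyl in place of 2-ethylphenyl gives an at least 2.0-fold higher number from compound 2 to compound 3 (0.30 log units; that floor lies within the scatter). On these data alone, the step is only a floor, so the true size of the change remains unknown, and the printed floor alone does not establish a difference beyond the scatter. Compound 2 remains the only compound with a numerical value, and the limit is now the commonest result in the set: the limit of > 50000 nM in this assay, at which 2 of the 3 values shown sit.

The compounds shown leave open whether the acetamido group itself or its place on the phenyl ring governs this result. A plain phenyl, a 4-aminophenyl or a 2-methylphenyl on the same nitrogen would separate these possibilities and show how much of the value of compound 2 depends on the ethyl group.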